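The Same Propanoyl Step Carried Onto a Second Core

The compounds below may be only part of what the source reports. "The series", "measured", "known", "first", "only" and "open" are said of these compounds alone.

Compound 2 `CCC(=O)NS(=O)(=O)c1ccc(-n2nc(C(F)F)cc2-c2ccc(Br)cc2)cc1CO` carries a hydroxymethyl group on its core, and in a functional assay on the whole organism (strain Wistar) with Rattus norvegicus as the target, read by paw edema (a lower number here means that less compound is needed, a higher number that more compound is needed for the effect), compound 2 gives 5.6 mg/kg. Compound 1 `CCC(=O)NS(=O)(=O)c1ccc(-n2nc(C(F)F)cc2-c2ccc(Br)cc2)cc1COC(=O)CC` differs from it in one place, (propanoyl in place of hydrogen on an oxygen on a saturated carbon), and in this assay compound 1 gives 7.9 mg/kg. That change made a 1.4-fold higher number from compound 2 to compound 1 (0.15 log units; within the scatter).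

Compound 3 `NS(=O)(=O)c1ccc(-n2nc(C(F)(F)F)cc2-c2ccc3c(c2)CCO3)cc1CO` is built on a different core; the difference between the two cores is not broken down here. In this assay compound 3 gives 22.3 mg/kg, the highest of the three numbers, with compound 1 nearest to it and compound 2 furthest from it.

Compound 4 `CCC(=O)OCc1cc(-n2nc(C(F)(F)F)cc2-c2ccc3c(c2)CCO3)ccc1S(N)(=O)=O` has not yet been measured. It differs from compound 3 by propanoyl in place of hydrogen on an oxygen on a saturated carbon, the same change as from compound 2 to compound 1, at a place described in the same words. The expectation rests on the earlier step of a 1.4-fold higher number from compound 2 to compound 1 (0.15 log units; within the scatter). The expected step is therefore a 1.2-fold higher number from compound 3 to compound 4 (0.08 log units; within the scatter). On that basis compound 4 is expected to give 27 mg/kg in this assay, with an expected range from 14 mg/kg to 55 mg/kg.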

Compound 4, dose for half-maximal effect: 8.5 mg/kg
For compound 4 the middle estimate is 3.2-fold (0.50 log units) above the measured one, outside the stated range (below it).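

In this assay the change from hydroxymethyl to (propanoyloxy)methyl gave a 2.6-fold lower number from compound 3 to compound 4 (0.42 log units; beyond the scatter), so the result on the core of compound 2, where the step stayed within the scatter, did not carry over to the core of compound 3. Going by these compounds alone, the two steps differ by more than the scatter of such steps allows: the same change on two cores in this assay, a 1.4-fold higher number (0.15 log units; within the scatter) from compound 2 to compound 1 and a 2.6-fold lower number (0.42 log units; beyond the scatter) from compound 3 to compound 4, 3.7-fold (0.57 log units) apart, beyond the scatter of two such steps This shows that, for these two pairs, the size of the step depends on the core that carries the change, so a step read on one core was a poor guide to the other; it does not show which part of the cores matters, as they differ in more than one place and each core offers only a single pair.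

Going by these compounds, it remains open whether an acetyl group or a longer chain such as butanoyl in place of propanoyl would behave the same way on each core. On these data alone, it is also open how the change would behave on a third core.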